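The source may hold more compounds than are shown below. What is called first, only, known or untested is meant among the compounds shown, and "the series" means these compounds.

Compound 1 `Fc1cccc(-c2nc(Nc3ccc(Cl)cc3)c3cc(F)ccc3n2)c1` gives 40300 nM in a functional assay on HT29-AK cells (Homo sapiens) for cytotoxicity, read by MTT assay, with a stated time of 48 h; on this read-out lower numbers stand for stronger inhibition and higher numbers for weaker inhibition. Compound 2 `Nc1ccc(Nc2nc(-c3cccc(F)c3)nc3ccc(F)cc23)cc1` carries amino in place of chloro on an aromatic carbon, and the change from compound 1 to compound 2 was an at least 1.2-fold higher number from compound 1 to compound 2 (0.09 log units; that floor lies within the scatter). In this assay compound 2 reaches only a limit, > 50000 nM, which is the limit of > 50000 nM in this assay, at which 1 of the 2 values shown sits. Compound 3 `Nc1ccccc1Nc1nc(-c2cccc(F)c2)nc2ccc(F)cc12` differs from compound 2 by 2-aminophenyl in place of 4-aminophenyl on a nitrogen on an aromatic ring. For the measured compounds named here, no measured step covers such a rearrangement, so no change beyond the scatter is expected from compound 2 to compound 3, a number no higher from compound 2 to compound 3 (the limit leaves the size open). Compound 3 is therefore estimated at 50000 nM, within 15000 nM to 150000 nM, with a real chance of again showing only a limit.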

Compound 3, half-maximal inhibitory concentration: > 50000 nM
Compound 3: no number, only a limit (the forecaster's own chance of this, stated with the estimate: 60%); the middle value sits exactly at the limit.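

With 2-aminophenyl in place of 4-aminophenyl on this nitrogen, compound 3 also reaches only a limit of the assay, > 50000 nM, so the step from compound 2 cannot be read. Against the chloro compound, the readable change is an at least 1.2-fold higher number from compound 1 to compound 3 (0.09 log units; that floor lies within the scatter), so neither position of the amino group gives a lower number in this assay. The ceiling of the assay now holds most of the results: the limit of > 50000 nM in this assay, at which 2 of the 3 values shown sit.

Going by these compounds, it remains open whether a methoxy or a carboxylic acid in place of the chloro would give a clearly lower number than compound 1. On these data alone, how far compound 2 and compound 3 truly differ also stays unknown.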